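Cyano for Trifluoromethyl: the Expected Clearance of Compound 4

This account rests on a few compounds, and the source may have more. Where it says the series, first, only, none or still open, it means among the compounds named here.

Compound 1 `CCCC(=O)Nc1cccnc1NCc1ccc(-c2ccccc2C(=O)OC)cc1`: 23 mL/min/kg
Compound 2 `CNC(=O)c1ccccc1-c1ccc(CNc2nccc(C)c2NC(=O)CC(F)(F)F)cc1`: 30 mL/min/kg
Compound 3 `COC(=O)c1ccccc1-c1ccc([C@@H](C)Nc2nccc(C)c2NC(=O)CC(F)(F)F)cc1`: 8 mL/min/kg

Of the compounds shown here, three have been measured in an in vivo ADME assay on the whole organism (Rattus norvegicus, strain Sprague Dawley) for pharmacokinetics; a higher number here means faster removal of the compound, a lower number slower removal. Compound 1 gives 23 mL/min/kg, compound 2 gives 30 mL/min/kg, and compound 3 gives 8 mL/min/kg. Compound 3 stands lowest of the three; its gap to compound 1, the nearest of the other two, lies beyond the usual scatter, as does its wider gap to compound 2. No two of the measured compounds differ in a single place, so no measured step can be read directly from them.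

Compound 4 `COC(=O)c1ccccc1-c1ccc([C@@H](C)Nc2nccc(C)c2NC(=O)CC#N)cc1` is the untested member. It differs from compound 3 in one place:

cyano in place of trifluoromethyl on a saturated chain carbon bound to a carbonyl carbon

Going by the values given here, nothing among the measured compounds shows what this particular exchange does in this assay, so the expectation rests on compound 3 alone, whose value 8 mL/min/kg is the starting point. The step from compound 3 to compound 4 is expected to be small, probably not beyond the scatter, with a slight lean toward a higher number: a 1.5-fold higher number from compound 3 to compound 4 (0.18 log units; within the scatter). Compound 4 is therefore estimated at 12 mL/min/kg, with a range from 5 mL/min/kg to 28 mL/min/kg.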

Compound 4, clearance: 18.5 mL/min/kg
Compound 4: middle estimate off by 1.5-fold (0.19 log units), on the low side; measured number inside the range.
By their numbers in this assay, from the lowest: compound 3; then compounds 4, 1 and 2 (each within the scatter of the next).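

In this assay, this exchange provides the only single-place comparison among the compounds shown, and the change of cyano in place of trifluoromethyl on a saturated chain carbon bound to a carbonyl carbon gives a 2.3-fold higher number from compound 3 to compound 4 (0.36 log units; beyond the scatter) with the rest of the structure held constant. The earlier compounds shown here could not show this, since they differ from one another in more than one place; the result establishes that the group at the end of this amide chain is not a silent position for the removal of the compound from the rat, although the step is modest. Nothing available here accounts for the direction or size of this step, so the result stands as an observation without a measured explanation.

The compounds shown leave open how other groups at this place would behave, such as a plain methyl, a hydroxyl, an amine or a longer chain, and whether the number follows any trend across such groups. They also leave open whether the same exchange would give a step of similar size on the core of compound 2, which carries a methyl amide rather than a methyl ester.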